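Benzylic methyl step in a dose-limited series

This account rests on a few compounds, and the source may have more. Where it says the series, first, only, none or still open, it means among the compounds named here.

Compound 1 `O=C1N=C(N2CCCC2)CN1c1ccc(Cl)cc1` gives a limit of > 300 mg/kg in a functional assay on the whole organism (strain NMRI BR) with Mus musculus as the target; a lower number here means that less compound is needed, a higher number that more compound is needed for the effect.
Compound 2 `O=C1N=C(N2CCOCC2)CN1Cc1ccccc1` gives a limit of > 300 mg/kg in this assay.
Compound 3 `O=C1N=C(N2CCOCC2)CN1Cc1ccccc1Cl` gives a limit of > 300 mg/kg in this assay.

Compound 2 stands at the limit of this assay, and so does every other value shown: the limit of > 300 mg/kg in this assay, at which 3 of the 3 values shown sit. Among the measured compounds shown here, no compound in the set has a number, so none can be ranked against another, and compound 2 cannot be placed above or below compound 1 or compound 3.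

For the measured compounds named here, the one step between measured compounds that differ in a single place, a step that the two limits leave unreadable from compound 2 to compound 3, is unreadable, as both of its ends are limits; it tells nothing about the size of any change.

Compound 4 `CC(c1ccccc1)N1CC(N2CCOCC2)=NC1=O` differs from compound 2 by methyl in place of hydrogen on a saturated chain carbon bound to an amide-type nitrogen in a ring and an aromatic carbon. Going by the values given here, no measured step covers this change, and the only step available, from compound 2 to compound 3, gives no size at all. There is therefore no basis for expecting a readable step in this assay in either direction, and the most likely outcome is that compound 4 again returns only a limit.

For compound 4 the expected value is 300 mg/kg, with a range of 100 mg/kg to 1000 mg/kg. The expected step is a number no higher from compound 2 to compound 4 (the limit leaves the size open), which is meant as no change beyond the scatter.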

Compound 4, dose for half-maximal effect: > 300 mg/kg
Compound 4: a limit, no number; the forecaster's own chance of this, stated with the estimate: 80%; the middle value lies on the limit itself.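

Compound 4 gives > 300 mg/kg in this assay, a limit and not a number. Compound 2 also stands at a limit, so no step can be read between compound 2 and compound 4, and the series stays where it was: the limit of > 300 mg/kg in this assay, at which 4 of the 4 values shown sit.

The compounds shown leave open whether any member reaches a measurable dose in this assay, and what size the methyl or chloro change has.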